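A single stereocentre changes in compound 3

The compounds below may be only part of what the source reports. "The series", "measured", "known", "first", "only" and "open" are said of these compounds alone.

Compound 1 `CCN(CC)S(=O)(=O)c1ccc(S(=O)(=O)N2CCC[C@@H](C(=O)N(C)C(C)C)C2)cc1`: 6200 nM
Compound 2 `CCOC(=O)[C@@H]1C[C@@H](O)CN(S(=O)(=O)c2ccc(S(=O)(=O)N(CC)CC)cc2)C1`: 7900 nM

Both compounds were tested in a functional assay on MIA PaCa-2 cells (Homo sapiens) for inhibition, read by MTT assay, with a stated time of 7 days; on this read-out higher numbers stand for weaker inhibition and lower numbers for stronger inhibition. Compound 2 gives 7900 nM and compound 1 gives 6200 nM. These two values lie within the usual scatter of repeated measurements, so the data place compound 2 level with compound 1 and do not rank them.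

The next compound, compound 3 `CCOC(=O)[C@@H]1C[C@H](O)CN(S(=O)(=O)c2ccc(S(=O)(=O)N(CC)CC)cc2)C1`, has the same atoms and bonds as compound 2 and differs only in configuration as drawn: the two compounds have the same atoms and bonds and differ only in configuration as drawn: 1 of 2 stereo elements differ; a stereocentre at a saturated ring carbon is drawn R in compound 2 and S in compound 3. A stereocentre at a saturated ring carbon is drawn R in compound 2 and S in compound 3. The connections stay the same, and only the spatial arrangement at that one carbon differs.

Among the compounds with values here, no measured pair here shows what such a change does in this assay, so the value of compound 2 is the only guide, and the direction cannot be predicted. The expected result is no shift beyond the scatter, with an estimated step of a 1.1-fold lower number from compound 2 to compound 3 (0.02 log units; within the scatter). For compound 3 the estimated value is 7500 nM, with an expected range of 3000 nM to 18000 nM.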

Compound 3, half-maximal inhibitory concentration: 1300 nM
Compound 3: the middle estimate sits 5.8-fold (0.76 log units) above what was measured, outside the stated range (below it).
By their numbers in this assay, from the lowest: compound 3; then compounds 1 and 2 (each within the scatter of the next).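

In this assay, the switch from R to S at a saturated ring carbon comes with a 6.1-fold lower number from compound 2 to compound 3 (0.78 log units; beyond the scatter), and a lower number here stands for stronger inhibition. This shows that the spatial arrangement at this one carbon matters in these cells, something compound 1 and compound 2 could not show, since they differ in more than one place. The shift can be traced to that single stereocentre: the fact that compounds 2 and 3 differ only in the configuration as drawn.

This is one pair, so it cannot say whether the S arrangement would give the same gain on another core or what inverting the second stereocentre, which stays the same in compound 2 and compound 3, would do. It also leaves open whether the gain depends on the hydroxyl group itself or would survive with an amine at that carbon, and whether it would hold if a carboxylic acid took the place of the ethyl ester.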